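Adding a Methoxy Group to Compound 2: What to Expect

The compounds below may be only part of what the source reports. "The series", "measured", "known", "first", "only" and "open" are said of these compounds alone.

Of the compounds shown here, three have so far been tested in an assay on isolated protein for inhibition of Alpha glucosidase (Homo sapiens), read by spectrophotometry, with stated times of 15 min and 30 min; on this read-out lower numbers stand for stronger inhibition and higher numbers for weaker inhibition. Compound 3 `O=C1NC(=S)S/C1=C\c1ccc(OCN2C(=O)c3ccccc3C2=O)cc1` gives 7910 nM, while compound 1 `COc1cc(/C=C2\SC(=S)NC2=O)ccc1OCN1C(=O)c2ccccc2C1=O` gives 16100 nM. The two differ by methoxy in place of hydrogen on an aromatic carbon, and this change produced a 2.0-fold higher number from compound 3 to compound 1 (0.31 log units; beyond the scatter). Compound 2 `O=C1NC(=S)S/C1=C\c1ccccc1OCN1C(=O)c2ccccc2C1=O` returns only a limit of > 100000 nM, so no number is known for it; it sits at the limit of > 100000 nM in this assay, at which 1 of the 3 values shown sits. How the core of compound 2 differs from that of compound 3 is not broken down here.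

Compound 4 `COc1cccc(/C=C2\SC(=S)NC2=O)c1OCN1C(=O)c2ccccc2C1=O` is still unmeasured. It differs from compound 2 by methoxy in place of hydrogen on an aromatic carbon, the same change as that between compound 3 and compound 1. Because that earlier change gave a 2.0-fold higher number from compound 3 to compound 1 (0.31 log units; beyond the scatter), a similar weakening is expected here, with a step that the limit leaves unreadable from compound 2 to compound 4 as the estimated step. Compound 4 is therefore expected to come in near 160000 nM, quite possibly again only as a limit.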

Compound 4, half-maximal inhibitory concentration: > 100000 nM
Compound 4: no number, only a limit (the forecaster's own chance of this, stated with the estimate: 80%); the middle value does not contradict the limit.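

Compound 2 and compound 4 both give only a limit in this assay, so no step between them can be read: the limit of > 100000 nM in this assay, at which 2 of the 4 values shown sit.

From the compounds shown here alone, whether methoxy in place of hydrogen changes inhibition on this core at all remains open.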